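Urea series notes: pentyl extension from compound 2

The source may report more compounds than this note shows. Statements on the series, on what has been measured and on what is new or still open speak of the compounds shown alone.

Among the measured compounds shown here, the series so far holds compound 1 `Cc1ccc(NC(=O)N[C@H](C)c2ccccc2)cc1`, compound 2 `Cc1ccc(NC(=O)N[C@@H](C)c2ccccc2)cc1` and compound 3 `CC(C)c1ccccc1NC(=O)N[C@H](C)c1ccccc1`. In an ADME assay on the whole organism with Oryza sativa as the target, tested at 1 uM (a lower number here means a stronger effect, a higher number a weaker effect of the compound at the concentration tested), compound 1 gives 98%, compound 2 gives 99% and compound 3 gives 101%. Compound 2 thus stands second highest of three numbers, within the scatter of both other compounds. For the measured compounds named here, the only measured step, a number 1 percentage points higher from compound 1 to compound 2 (within the scatter), goes with the fact that compounds 1 and 2 differ only in the configuration as drawn and stays within the scatter. Compound 4 `CCCCCCc1ccc(NC(=O)N[C@@H](C)c2ccccc2)cc1` carries pentyl in place of hydrogen on a saturated chain carbon bound to an aromatic carbon. Going by the values given here, no measured step alters a chain in this way, so the numbers give no direction; the three values sit close together. A step of a number 2 percentage points lower from compound 2 to compound 4 (within the scatter) is expected, meaning none beyond the scatter. Compound 4 is estimated at 97%, with a range from 85% to 104%.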

Compound 4, a percentage reported as activity, at one concentration (the size of the read-out at that concentration, not a potency): 100%
Estimate against measurement, compound 4: 3 percentage points below; the range from low to high includes it.
By their numbers in this assay, from the lowest: compounds 1, 2, 4 and 3 (each within the scatter of the next).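

Pentyl in place of hydrogen on a saturated chain carbon bound to an aromatic carbon, the same difference as methyl to hexyl, gives in this assay a step of a number 1 percentage points higher from compound 2 to compound 4 (within the scatter). Among the compounds shown here, this is the first reading at this position, where the earlier step concerned only configuration, and the longer chain leaves the number within the scatter. Nothing known here bears on the reason for this outcome.

Open remains whether an amine or a carboxylic acid at the end of this chain, or a chain longer than hexyl, would move the number beyond the scatter. Also open, going by these compounds, is whether the same change behaves alike in the configuration of compound 1.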